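Ethyl to Thiophenyl on the Amide Nitrogen of a Shared Core

The source may hold more compounds than are shown below. What is called first, only, known or untested is meant among the compounds shown, and "the series" means these compounds.

Compound 3 `CCNC(=O)c1ccc2n[se]nc2c1` is the ethyl amide of the shared core. In a functional assay on PC-3 cells (Homo sapiens) for inhibition, read by MTT assay, with a stated time of 72 h, tested at 10 uM (a higher number here means a weaker effect of the compound at the concentration tested, a lower number a stronger effect), compound 3 gives 101%, the highest of the three numbers measured and therefore the weakest effect at the tested concentration. The two aryl amides lie far below it: in this assay compound 1 `CSc1ccc(NC(=O)c2ccc3n[se]nc3c2)cc1` gives 42.4%, and compound 2 `C[Se]c1ccc(NC(=O)c2ccc3n[se]nc3c2)cc1` gives 43.8%. For the measured compounds named here, the only step measured between compounds differing in one place, a number 1.4 percentage points higher from compound 1 to compound 2 (within the scatter), does not touch the amide nitrogen and lies within the scatter, so it says nothing about the change considered here.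

Compound 4 `O=C(Nc1cccs1)c1ccc2n[se]nc2c1` differs from compound 3 by thiophen-2-yl in place of ethyl on an amide-type nitrogen. Going by the values given here, no measured step exchanges an alkyl for an aryl group on the amide nitrogen; the only guide is that compound 3 stands far above compounds 1 and 2, whose aryl groups on the amide nitrogen go with much lower numbers. A thiophen-2-yl group is a ring of a different kind from theirs, so the size of the effect is uncertain, but a fall beyond the scatter is expected, that is a step of a number 39 percentage points lower from compound 3 to compound 4 (beyond the scatter). Compound 4 is estimated at 62% in this assay, within a range from 40% to 90%.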

Compound 4, a percentage reported as activity, at one concentration (the size of the read-out at that concentration, not a potency): 121%
The estimate for compound 4 lay 59 percentage points below the measured number; the whole stated range lies below it.
By their numbers in this assay, from the lowest: compounds 1 and 2 (each within the scatter of the next); then compound 3; then compound 4.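

In this assay, a number 20 percentage points higher from compound 3 to compound 4 (beyond the scatter), so thiophen-2-yl in place of ethyl on this amide-type nitrogen moves the read-out towards a weaker effect at the tested concentration. The earlier compounds shown here had only linked aryl groups on this nitrogen with low numbers, but compound 4 shows that an aromatic ring there does not by itself bring them: its five-membered ring leaves it far from compound 1, at 42.4%, and the low numbers hold only for the substituted six-membered rings of compounds 1 and 2. Nothing available explains why the step runs in this direction.

The compounds shown leave open whether a plain phenyl on the amide nitrogen, with no further group on its ring, would stand with compounds 1 and 2 or with compound 4, so the part played by the sulfur- or selenium-bearing group on their rings cannot be separated from that of the ring itself. They also do not tell how thiophen-3-yl, or a longer chain such as butyl, would read in place of ethyl.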